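This account rests on a few compounds, and the source may have more. Where it says the series, first, only, none or still open, it means among the compounds named here.

Of the compounds shown here, two built on the shared core have been measured in a functional assay on A2780 cells (Homo sapiens) for inhibition, read by sulforhodamine B assay, with a stated time of 72 h; on this read-out higher numbers stand for weaker inhibition and lower numbers for stronger inhibition. Compound 1 (`O=C(NCc1ccc(S(=O)(=O)c2cccc(C(F)(F)F)c2)cc1)c1cc2cnccc2[nH]1`) gives 3 nM, and compound 2 (`O=C(NCc1ccc(S(=O)(=O)c2ccc(F)c(F)c2)cc1)c1cc2cnccc2[nH]1`) gives 14 nM, the higher of the two numbers and therefore the weaker inhibition. Compound 3 (`O=C(NCc1ccc(S(=O)(=O)c2ccc(F)cc2)cc1)c1cc2cnccc2[nH]1`) has not yet been measured. It differs from compound 2 by hydrogen in place of fluoro on an aromatic carbon, with hydrogen in place of fluoro on an aromatic carbon, so that 3,4-difluorophenyl becomes 4-fluorophenyl. Among the compounds with values here, only one measured step bears on this change: a 4.7-fold higher number from compound 1 to compound 2 (0.67 log units; beyond the scatter). It came with 3,4-difluorophenyl in place of 3-(trifluoromethyl)phenyl on a sulfonyl sulfur, and it was modest, though beyond the scatter. The removal of a single fluoro group is a smaller edit than that exchange, so a step no larger than that one is expected in this assay, and most likely none beyond the scatter. The data give no direction for it. The expected step is a 1.2-fold lower number from compound 2 to compound 3 (0.07 log units; within the scatter). For compound 3 the estimated value is 12 nM, with an expected range from 4 nM to 35 nM.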

Compound 3, half-maximal inhibitory concentration: 16 nM
Compound 3: the middle estimate sits 1.3-fold (0.12 log units) below what was measured; the measured number falls inside the stated range.
By their numbers in this assay, from the lowest: compound 1; then compounds 2 and 3 (each within the scatter of the next).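

In this assay, the change from 3,4-difluorophenyl to 4-fluorophenyl removes the fluoro group ortho to the remaining fluoro group and gives a 1.1-fold higher number from compound 2 to compound 3 (0.06 log units; within the scatter), so in this read-out that aromatic carbon carries hydrogen as readily as fluoro. The exchange on the sulfonyl sulfur gives a 5.3-fold higher number from compound 1 to compound 3 (0.73 log units; beyond the scatter), which is beyond the scatter, just as a 4.7-fold higher number from compound 1 to compound 2 (0.67 log units; beyond the scatter) is, so among these three compounds the 3-(trifluoromethyl)phenyl group of compound 1 alone stands apart, whether the ring it is compared with carries one fluoro group or two. No supporting measurement is available to explain either the absence of a change at this position or the gap to compound 1.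

The compounds shown leave open whether the remaining fluoro group contributes at all, since a plain phenyl group, or a methoxy group or an amine in its place, would be needed to test that. They also leave open whether the number for compound 1 depends on the trifluoromethyl group itself, which a chloro or methyl group on the same ring could help to settle.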